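Swapping the Benzyl Substituent: From Methoxy to Difluoro

This account rests on a few compounds, and the source may have more. Where it says the series, first, only, none or still open, it means among the compounds named here.

Of the compounds shown here, three sharing one core have been measured in a functional assay on SW 1116 cells (Homo sapiens) for antiproliferative activity, read by MTT assay, with a stated time of 24 h; a lower number here means a stronger inhibitor, a higher number a weaker inhibitor. Compound 1 `O=[N+]([O-])c1ccccc1CSc1nnc(-c2ccc3c(c2)OCCO3)n1-c1ccccc1` gives 8300 nM. Compound 2 `Clc1ccccc1CSc1nnc(-c2ccc3c(c2)OCCO3)n1-c1ccccc1` gives 9670 nM. Compound 3 `COc1cccc(CSc2nnc(-c3ccc4c(c3)OCCO4)n2-c2ccccc2)c1` gives 10100 nM, and the other two sit close to it: a 1.2-fold higher number from compound 1 to compound 3 (0.09 log units; within the scatter), and a 1.0-fold higher number from compound 2 to compound 3 (0.02 log units; within the scatter). Between compound 1 and compound 2 the picture is the same, with a 1.2-fold higher number from compound 1 to compound 2 (0.07 log units; within the scatter). In short, none of the three differs from another beyond the scatter.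

Compound 4 `Fc1ccc(CSc2nnc(-c3ccc4c(c3)OCCO4)n2-c2ccccc2)c(F)c1` has not yet been measured. It differs from compound 3 in one place: 2,4-difluorophenyl in place of 3-methoxyphenyl on a saturated chain carbon bound to a sulfur

Within the data shown here, the steps that bear on this are the two that also change the group on the saturated chain carbon bound to a sulfur, namely the steps from compound 1 and from compound 2 to compound 3. Both were within the scatter, so the exchange of one benzyl group for another has so far left this assay unmoved. The same is therefore expected here, with no step beyond the scatter: a 1.1-fold lower number from compound 3 to compound 4 (0.03 log units; within the scatter). Compound 4 is estimated at 9500 nM, within a range from 4500 nM to 20000 nM.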

Compound 4, half-maximal inhibitory concentration: 7830 nM
The estimate for compound 4 lay 1.2-fold (0.08 log units) above the measured number; the measured number falls inside the stated range.
By their numbers in this assay, from the lowest: compounds 4, 1, 2 and 3 (each within the scatter of the next).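

With 2,4-difluorophenyl, the hydrogen-bond acceptor counted on 3-methoxyphenyl is gone, yet this assay shows no step beyond the scatter: a 1.3-fold lower number from compound 3 to compound 4 (0.11 log units; within the scatter), a 1.2-fold lower number from compound 2 to compound 4 (0.09 log units; within the scatter), and a 1.1-fold lower number from compound 1 to compound 4 (0.03 log units; within the scatter). On the saturated chain carbon bound to a sulfur, all four substituted phenyl groups therefore remain indistinguishable in this assay, and losing that acceptor in this one change leaves the number within the scatter. Nothing available explains why this position tolerates these exchanges.

The compounds shown leave open whether an amine or a carboxylic acid on the phenyl group, or a longer chain in place of the benzyl group, would produce a step beyond the scatter. They also leave open whether changes elsewhere on the shared core would move the number further than these exchanges have.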